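The compounds below may be only part of what the source reports. "The series", "measured", "known", "first", "only" and "open" are said of these compounds alone.

Measured so far in an assay on microsomes from liver for inhibition of 3-hydroxy-3-methylglutaryl-coenzyme A reductase (Rattus norvegicus), read by scintillation counting, with stated times of 0.5 h and 0.75 h; a higher number here means a weaker inhibitor, a lower number a stronger inhibitor:
compound 1 `CC(C)c1c(C(=O)NCc2ccccc2)nc(-c2ccc(F)cc2)n1CC[C@@H](O)C[C@@H](O)CC(=O)O` gives 7.9 nM
compound 2 `Cc1ccc(CNC(=O)c2nn(-c3ccc(F)cc3)c(CC[C@@H](O)C[C@@H](O)CC(=O)O)c2C(C)C)cc1` gives 1 nM
compound 3 `O=C(O)C[C@H](O)C[C@H](O)CCn1c(-c2ccc(F)cc2)nc(C(=O)NCc2ccccc2F)c1C1CC1` gives 1.5 nM

Among these three, compound 1 stands at the highest number. Compound 3 lies nearest to it, at a lower number that is beyond the scatter, and compound 2 lies furthest, also at a lower number beyond the scatter. Both compound 2 and compound 3 differ from compound 1 in more than one place, so their values show only that each sits lower than compound 1; no single-point step can be read from them.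

Compound 4 `Cc1c(C(=O)NCc2ccccc2)nc(-c2ccc(F)cc2)n1CC[C@@H](O)C[C@@H](O)CC(=O)O` has not yet been measured in this assay. It differs from compound 1 in one place: methyl in place of isopropyl on an aromatic carbon. Within the data shown here, no measured pair in the set isolates this exchange, so the expectation rests on the change alone. The step from compound 1 to compound 4 is expected to run toward a higher number, beyond the scatter, estimated at a 5.1-fold higher number from compound 1 to compound 4 (0.70 log units; beyond the scatter). For compound 4 the estimated value in this assay is 40 nM, with a range from 10 nM to 160 nM.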

Compound 4, half-maximal inhibitory concentration: 94 nM
Compound 4: middle estimate off by 2.4-fold (0.37 log units), on the low side, and the stated range covers the measured number.
By their numbers in this assay, from the lowest: compounds 2 and 3 (each within the scatter of the next); then compound 1; then compound 4.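

In this assay, among these compounds, this is the first exchange confined to one place, and it gives a large step: methyl in place of isopropyl yields a 12-fold higher number from compound 1 to compound 4 (1.08 log units; beyond the scatter). With the benzylcarbamoyl, 4-fluorophenyl and 6-carboxy-3,5-dihydroxyhexyl groups held fixed, inhibition therefore depends strongly on which of these two alkyl groups sits on this aromatic carbon. Nothing measured here accounts for the loss.

Open, from the compounds shown here alone, is how an ethyl group, a tert-butyl group or a plain hydrogen on this carbon would stand against isopropyl and methyl on the core of compound 1. Also open, going by these compounds, is whether the same exchange would give a step of similar size in the settings of compound 2 and compound 3.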